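A few compounds are considered here, and "the series" means these few. Any claim that something is new, unique, unknown or untested is made for them only; others in the source may bear on it.

In an ADME assay on Vero cells (Chlorocebus sabaeus) for cytotoxicity, with a stated time of 7 days (on this read-out higher numbers stand for lower toxicity in this test and lower numbers for higher toxicity in this test), the measured compounds are these:

Compound 1 `COc1ccc2[nH]c(C(=O)N3CC(=O)N(Cc4ccccc4)[C@@H](CCc4ccccc4)C3)cc2c1` gives > 30000 nM, which is a limit of the assay.
Compound 2 `COc1ccc2[nH]c(C(=O)N3CC(=O)N(Cc4ccccc4)[C@@H](CN4CCCCC4)C3)cc2c1` gives 76900 nM.
Compound 3 `COc1ccc2[nH]c(C(=O)N3CC(=O)N(Cc4ccccc4)[C@@H](CN4CCC(C)CC4)C3)cc2c1` gives > 30000 nM, which is a limit of the assay.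

Compound 3 therefore stands at a limit rather than at a number, and (the limit of > 30000 nM in this assay, at which 2 of the 3 values shown sit). Compound 4 `COc1ccc2[nH]c(C(=O)N3CC(=O)N(Cc4ccccc4)[C@@H](COc4ccc(F)cc4)C3)cc2c1` differs from compound 3 in one place: 4-fluorophenoxy in place of 4-methylpiperidin-1-yl on a saturated chain carbon bound to a saturated ring carbon. The two measured steps that end at the same position, a step that the two limits leave unreadable from compound 1 to compound 3 and a step that the limit leaves unreadable from compound 2 to compound 3, are both of unreadable size, so they give no size for the new step and no direction. The step that the limit leaves unreadable from compound 3 to compound 4 is expected to stay within the usual scatter, with a further limit the most likely outcome. Compound 4 is estimated at 50000 nM, in a range from 20000 nM to 150000 nM.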

Compound 4, half-maximal cytotoxic concentration: 33200 nM
Beside the measured number, compound 4's estimate is 1.5-fold (0.18 log units) above it; the measured number falls inside the stated range.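

In this assay, among the compounds shown here, 4-fluorophenoxy in place of piperidin-1-yl on a saturated chain carbon bound to a saturated ring carbon gives the first readable step at this position, a 2.3-fold lower number from compound 2 to compound 4 (0.36 log units; beyond the scatter). This step is modest but beyond the scatter, so changing the group here can move the read-out, in this case towards higher toxicity in this test. The steps to compound 4 from compound 1 and compound 3 cannot be read: the limit of > 30000 nM in this assay, at which 2 of the 4 values shown sit.

The compounds shown do not separate the oxygen, the fluorine and the aromatic ring as the source of the readable step. From the compounds shown here alone, how a carboxylic acid at this position would read also remains open.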